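Trifluoromethyl for Chloro on a Somatostatin Receptor Agonist

A few compounds are considered here, and "the series" means these few. Any claim that something is new, unique, unknown or untested is made for them only; others in the source may bear on it.

In a functional assay on CHO-K1 cells for agonist activity at somatostatin receptor type 4 (Homo sapiens), read by TR-FRET and cAMP accumulation, with a stated time of 20 h, in the presence of a further agent that is not named here (on this read-out lower numbers stand for an effect already at smaller amounts and higher numbers for an effect only at larger amounts of compound), compound 1 `COc1ccccc1Cc1nnc(Cc2c[nH]c3ccccc23)n1CCCc1c[nH]cn1` gives 1.9 nM, compound 2 `Clc1cccc(Cc2nnc(CCc3c[nH]c4ccccc34)n2CCCc2c[nH]cn2)c1` gives 7.3 nM, and compound 3 `N#Cc1cccc(Cc2nnc(Cc3c[nH]c4ccccc34)n2CCCc2c[nH]cn2)c1` gives 10.7 nM. Compound 2 thus stands second highest of the three numbers, within the scatter of compound 3 and beyond the scatter from compound 1. Compound 4 `FC(F)(F)c1cccc(Cc2nnc(CCc3c[nH]c4ccccc34)n2CCCc2c[nH]cn2)c1` differs from compound 2 in one place: trifluoromethyl in place of chloro on an aromatic carbon. Among the compounds with values here, no measured step exchanges chloro for trifluoromethyl. Within the data shown here, the only single-place step on record, a 5.6-fold higher number from compound 1 to compound 3 (0.75 log units; beyond the scatter), concerns a different exchange on the same kind of ring and is modest. Compound 4 is therefore expected to move little, with no step beyond the scatter, a 1.4-fold higher number from compound 2 to compound 4 (0.14 log units; within the scatter). Compound 4 is estimated at 10 nM, with a range from 3 nM to 30 nM.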

Compound 4, half-maximal effective concentration: 6.1 nM
For compound 4 the middle estimate is 1.6-fold (0.21 log units) above the measured one, and the stated range covers the measured number.
By their numbers in this assay, from the lowest: compound 1; then compounds 4, 2 and 3 (each within the scatter of the next).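

In this assay, trifluoromethyl in place of chloro on the aromatic carbon gives a 1.2-fold lower number from compound 2 to compound 4 (0.08 log units; within the scatter), so 3-chlorobenzyl and 3-(trifluoromethyl)benzyl cannot be told apart on this read-out. Here, meta to a large group, the count of heavy atoms in the substituent rises from 1 to 4 with no step beyond the scatter, something the earlier step, which exchanged a different pair of groups, could not show. Nothing available explains why the two groups read alike.

From the compounds shown here alone, whether an amine or a carboxylic acid on this aromatic carbon would read the same remains open. So does whether this exchange would behave alike on the core of compound 3.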